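A few compounds are considered here, and "the series" means these few. Any claim that something is new, unique, unknown or untested is made for them only; others in the source may bear on it.

Series notes. Compound 1 `CCc1ccc(NC2=CC(=O)c3c(nc4n3[C@H]3OC[C@@H](O)[C@H]3OC4)C2=O)cc1` in a functional assay on MCF7 cells (Homo sapiens) for inhibition, read by sulforhodamine B assay (on this read-out lower numbers stand for stronger inhibition and higher numbers for weaker inhibition), gives 8990 nM. Compound 2 `O=C1C=C(Nc2ccccc2F)C(=O)c2c1nc1n2[C@H]2OC[C@@H](O)[C@H]2OC1` in this assay gives 3640 nM. Of the two numbers, compound 1 holds the higher one, and its gap to compound 2 lies beyond the scatter. Compound 3 `CCCN(CCC)C1=CC(=O)c2c(nc3n2[C@H]2OC[C@@H](O)[C@H]2OC3)C1=O` differs from compound 1 by dipropylamino in place of (4-ethylphenyl)amino on a double-bonded ring carbon. Among the measured compounds shown here, both measured compounds keep a ring at that place, and no measured step covers its removal, so the estimate rests on the change alone; a step of moderate size toward a higher number is expected, a 1.7-fold higher number from compound 1 to compound 3 (0.22 log units; within the scatter). In this assay compound 3 is thus expected near 15000 nM, within a range from 5000 nM to 50000 nM.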

Compound 3, half-maximal inhibitory concentration: > 16000 nM
Compound 3 was reported as a limit; the forecaster's own chance of this, stated with the estimate: 20%; middle value at least 1.0-fold (0.02 log units) away from the limit.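

On the double-bonded ring carbon, dipropylamino in place of (4-ethylphenyl)amino gives in this assay an at least 1.7-fold higher number from compound 1 to compound 3 (0.25 log units; that floor lies within the scatter). Compound 3 stands only as a limit, > 16000 nM. Losing both the aromatic ring and the hydrogen-bond donor at this place therefore brings no lower number, and the full size of the step cannot be read: the limit of > 16000 nM in this assay, at which 1 of the 3 values shown sits.

Whether the ring or the donor accounts for the step stays open. Propylamino, which keeps a donor without a ring, would help separate the two.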